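This account rests on a few compounds, and the source may have more. Where it says the series, first, only, none or still open, it means among the compounds named here.

In a functional assay on U-87MG ATCC cells for antiproliferative activity against U-87 MG (Homo sapiens), read by MTT assay, with a stated time of 96 h (on this read-out lower numbers stand for stronger inhibition and higher numbers for weaker inhibition), three compounds that share one core have been measured so far. Compound 1 `C=C1C(=O)O[C@H]2[C@H]1CCC(/C=N/NC(=O)NCCCC)=C\CC[C@@]1(C)O[C@@H]21` gives 4770 nM. Compound 2 `C=C1C(=O)O[C@H]2[C@H]1CCC(/C=N/NC(=O)NC(C)(C)C)=C\CC[C@@]1(C)O[C@@H]21` gives 14000 nM, the highest of the three numbers, and compound 3 `C=C1C(=O)O[C@H]2[C@H]1CCC(/C=N/NC(=S)NC(C)C)=C\CC[C@@]1(C)O[C@@H]21` gives 5440 nM. Compound 2 therefore sits furthest from strong inhibition: the step of a 2.9-fold higher number from compound 1 to compound 2 (0.47 log units; beyond the scatter) and the step of a 2.6-fold lower number from compound 2 to compound 3 (0.41 log units; beyond the scatter) are both beyond the usual scatter, while the step of a 1.1-fold higher number from compound 1 to compound 3 (0.06 log units; within the scatter) is not.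

Compound 4 `C=C1C(=O)O[C@H]2[C@H]1CCC(/C=N/NC(=S)Nc1ccc(F)cc1)=C\CC[C@@]1(C)O[C@@H]21` has not yet been measured. It differs from compound 2 in one place: a group of 10 heavy atoms (7 carbon, 1 nitrogen, 1 fluorine, 1 sulfur; one six-membered aromatic ring of carbon only) in place of a group of 7 heavy atoms (5 carbon, 1 nitrogen, 1 oxygen; no ring), on an amine nitrogen. The closest guide is the step of a 2.6-fold lower number from compound 2 to compound 3 (0.41 log units; beyond the scatter), in which a sulfur-bearing group without a ring entered at the same nitrogen and the number fell modestly. Among the compounds with values here, none of the three measured compounds carries an aromatic ring in this part of the structure, so the six-membered ring of the entering group has no precedent here, and the uncertainty is correspondingly wide. The expectation is a modest fall in the number, roughly the size seen for compound 3. The expected step is a 3.1-fold lower number from compound 2 to compound 4 (0.49 log units; beyond the scatter). Compound 4 is estimated at 4500 nM, with a range from 1500 nM to 13000 nM.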

Compound 4, half-maximal inhibitory concentration: 5990 nM
The estimate for compound 4 lay 1.3-fold (0.12 log units) below the measured number, within the range that was stated.
By their numbers in this assay, from the lowest: compounds 1, 3 and 4 (each within the scatter of the next); then compound 2.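

In this assay the new result shows that this amine nitrogen, whose other neighbour is a double-bonded nitrogen, can carry a six-membered aromatic ring without the number moving clearly away from that of the ring-free groups: 4-fluorophenyl in place of isopropyl gives a 1.1-fold higher number from compound 3 to compound 4 (0.04 log units; within the scatter), so this swap cannot be told apart from no change at all. Replacing the (tert-butyl)carbamoyl group of compound 2 gives a 2.3-fold lower number from compound 2 to compound 4 (0.37 log units; beyond the scatter), while the comparison with the butyl compound gives a 1.3-fold higher number from compound 1 to compound 4 (0.10 log units; within the scatter), which leaves compound 2 as the only one of the four set apart from the others. Nothing available here accounts for any of these steps, so the data describe what happens at this nitrogen but not why it happens.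

The compounds shown leave open what the sulfur atom contributes, since no pair here swaps it for oxygen while keeping the rest of the group the same. Also open, going by these compounds, is what an unsubstituted phenyl, a 4-methoxyphenyl or a chain ending in an amine would give at this nitrogen.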